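Stereochemical inversion at the ring carbon of compound 3

This account rests on a few compounds, and the source may have more. Where it says the series, first, only, none or still open, it means among the compounds named here.

Compound 1 `C/C=C1\C(=O)O[C@H](c2ccc(OC)cc2)[C@H]1C` — 124%
Compound 2 `C=C1C(=O)O[C@H](c2ccc3ccccc3c2)[C@H]1C` — 4%
Compound 3 `C=C1C(=O)O[C@@H](c2ccc3ccccc3c2)[C@H]1c1ccccc1` — 6%

In a functional assay on MIA PaCa-2 cells (Homo sapiens) for cytotoxicity, read by MTT assay, with a stated time of 72 h, tested at 10 uM (on this read-out higher numbers stand for a weaker effect at the one concentration tested and lower numbers for a stronger effect), compound 3 gives 6%. Among the three measured compounds it stands second highest, within the scatter of compound 2, while compound 1 lies far above it. Compound 4 `C=C1C(=O)O[C@H](c2ccc3ccccc3c2)[C@H]1c1ccccc1` keeps every atom and bond of compound 3: the two compounds have the same atoms and bonds and differ only in configuration as drawn: 1 of 2 stereo elements differ; a stereocentre at a saturated ring carbon is drawn R in compound 3 and S in compound 4. Among the compounds with values here, no step between two measured compounds of this kind is available, so the size of this change in this assay is uncertain; the low read-outs of compound 2 and compound 3 suggest that compound 4 will also stay in the lower range, though a step beyond the scatter cannot be excluded. Compound 4 is therefore estimated at 12% (range 3% to 50%), an expected step of a number 6 percentage points higher from compound 3 to compound 4 (within the scatter).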

Compound 4, a percentage reported as activity, at one concentration (the size of the read-out at that concentration, not a potency): 3%
Compound 4: middle estimate off by 9 percentage points, on the high side; the range from low to high includes it.
By their numbers in this assay, from the lowest: compounds 4, 2 and 3 (each within the scatter of the next); then compound 1.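

In this assay, inverting the saturated ring carbon gives a number 3 percentage points lower from compound 3 to compound 4 (within the scatter), so in this pair the drawn configuration at that carbon makes no difference beyond the scatter. This is a direct reading of that configuration: the fact that compounds 3 and 4 differ only in the configuration as drawn. Phenyl in place of methyl on a saturated ring carbon gives a number 1 percentage points lower from compound 2 to compound 4 (within the scatter), so the read-out stays low with either group. The compounds shown leave open whether a carboxylic acid or an amine on that carbon would keep the read-out this low. A single concentration also leaves open whether the effects of compound 3 and compound 4 would differ at other concentrations.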